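Replacing pyridin-3-yl with ethoxy on compound 3

A few compounds are considered here, and "the series" means these few. Any claim that something is new, unique, unknown or untested is made for them only; others in the source may bear on it.

Of the compounds shown here, three have been measured in a functional assay on a cell-free system (plasma, Homo sapiens) for inhibition, with Plasma (Rattus norvegicus) as the target; on this read-out higher numbers stand for weaker inhibition and lower numbers for stronger inhibition. Compound 1 (`O=c1cc(N2CCNCC2)c2c(OCc3ccccc3)cccc2o1`) gives 429000 nM, compound 2 (`O=c1cc(N2CCNCC2)c2ccc(OCc3ccccc3)cc2o1`) gives 78800 nM, and compound 3 (`Cc1c(OCc2cccnc2)ccc2c(N3CCNCC3)cc(=O)oc12`) gives 1420 nM. Compound 3 holds the lowest number of the three, and its gaps to compound 2 and to compound 1 both lie beyond the scatter.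

The next compound, compound 4 (`CCOCOc1ccc2c(N3CCNCC3)cc(=O)oc2c1C`), departs from compound 3 in one place (ethoxy in place of pyridin-3-yl on a saturated chain carbon bound to an oxygen on an aromatic ring). Within the data shown here, no two measured compounds differ in only one place, so the data hold no measured step for this change, and any expectation is a loose one. It rests on the spread of the three values: compound 3, at 1420 nM, already sits at the low end, while compound 2, at 78800 nM, is the nearest higher number. In this assay the expected change is a step of a 6.3-fold higher number from compound 3 to compound 4 (0.80 log units; beyond the scatter), toward a higher number and weaker inhibition, probably beyond the scatter. Compound 4 is estimated at 9000 nM, with an expected range of 1500 nM to 50000 nM.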

Compound 4, half-maximal inhibitory concentration: 1900 nM
Beside the measured number, compound 4's estimate is 4.7-fold (0.68 log units) above it, and the stated range covers the measured number.
By their numbers in this assay, from the lowest: compounds 3 and 4 (each within the scatter of the next); then compound 2; then compound 1.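

In this assay, putting ethoxy in place of pyridin-3-yl on a saturated chain carbon bound to an oxygen on an aromatic ring gives a 1.3-fold higher number from compound 3 to compound 4 (0.13 log units; within the scatter), so this pair cannot be told apart on this read-out. Among these compounds, this is the first step that changes one place alone, and it shows that, on the core shared by compound 3 and compound 4, a six-membered aromatic ring with 1 hetero atom is not required at this place for a number at this level: ethoxy, with no ring and 3 heavy atoms against 6, serves equally well. No measurement offered here explains why the two groups give matching numbers.

What a longer chain such as butoxy, an amine such as dimethylamino or a carboxylic acid would do at this place remains open, since the compounds shown carry only these two groups there. A single step also leaves open whether the same exchange would give a matching result on any other core.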